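Moving the nitrile to a new position on the phenyl

The source may report more compounds than this note shows. Statements on the series, on what has been measured and on what is new or still open speak of the compounds shown alone.

Three close relatives of one acid share a core and differ only in the aryl group attached to an aromatic nitrogen of the five-membered ring with 3 nitrogen. Compound 1 `COc1ccc(/C=C\C(=O)O)c(OCc2cn(-c3ccccc3I)nn2)c1CC=C(C)C` carries an iodine-bearing phenyl there and in a functional assay on T47D cells (Homo sapiens) for cytotoxicity, read by MTT assay, with a stated time of 24 h (on this read-out lower numbers stand for stronger inhibition and higher numbers for weaker inhibition), compound 1 gives "not determined" (no result reported). Compound 2 `COc1ccc(/C=C\C(=O)O)c(OCc2cn(-c3ccccc3C#N)nn2)c1CC=C(C)C` carries a 2-cyanophenyl and gives 8800 nM. Among the compounds with values here, compound 3 `COc1cccc(-n2cc(COc3c(/C=C\C(=O)O)ccc(OC)c3CC=C(C)C)nn2)c1` carries a 3-methoxyphenyl and gives 20400 nM, the higher of the two available numbers, meaning weaker inhibition; its only neighbour with a number is compound 2, and the step of a 2.3-fold higher number from compound 2 to compound 3 (0.37 log units; beyond the scatter) is modest yet beyond the scatter.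

Compound 4 `COc1ccc(/C=C\C(=O)O)c(OCc2cn(-c3ccc(C#N)cc3)nn2)c1CC=C(C)C` is the next member. Relative to compound 3 the change is 4-cyanophenyl in place of 3-methoxyphenyl on an aromatic nitrogen. Within the data shown here, the only measured step that bears on it is a 2.3-fold higher number from compound 2 to compound 3 (0.37 log units; beyond the scatter), a modest rise when a nitrile-bearing phenyl gave way to a methoxy-bearing one. Compound 4 brings a nitrile back, though at a different position on the phenyl, so a step of similar size in the opposite direction is expected, back toward the number of compound 2, and the changed position widens the range. For compound 4 the expected step is a 1.7-fold lower number from compound 3 to compound 4 (0.23 log units; within the scatter). Compound 4 is therefore estimated at 12000 nM, within a range from 5000 nM to 30000 nM.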

Compound 4, half-maximal inhibitory concentration: 10200 nM
The estimate for compound 4 lay 1.2-fold (0.07 log units) above the measured number; the measured number falls inside the stated range.
By their numbers in this assay, from the lowest: compounds 2, 4 and 3 (each within the scatter of the next, the first and the last beyond it).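

The swap of 2-cyanophenyl for 4-cyanophenyl gives a 1.2-fold higher number from compound 2 to compound 4 (0.06 log units; within the scatter) and so, in this assay, these two placements of the nitrile on the phenyl cannot be told apart. The swap of 3-methoxyphenyl for 4-cyanophenyl gives a 2.0-fold lower number from compound 3 to compound 4 (0.30 log units; within the scatter) and so cannot be separated from the ordinary variation between repeat measurements, which means the clear gap seen between the 2-cyanophenyl and the 3-methoxyphenyl does not extend to both nitrile compounds. No independent data are available to explain these readings.

Going by these compounds, all the numbers so far come from aryl groups on the aromatic nitrogen, and they span a narrow range, so it remains open whether this place tolerates very different groups, such as a phenyl carrying an amine or a carboxylic acid, or a longer chain in place of the phenyl. A single cell line and a single read-out also leave open whether the close agreement between the two nitrile compounds would hold in any other setting.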